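Same Substituent Swap Repeated on a Second Core

The source may hold more compounds than are shown below. What is called first, only, known or untested is meant among the compounds shown, and "the series" means these compounds.

Of the compounds shown here, three have been measured in an ADME assay on a cell-free system (plasma, Rattus norvegicus) for protein binding; on this read-out lower numbers stand for a smaller free fraction and higher numbers for a larger free fraction. Compound 1 `CC[C@H](COC)n1c(=O)c(C)nc2c(-c3ccc(Cl)cc3Cl)ncnc21` gives 0.022 in this assay. Compound 2 `CC[C@@H](C1CC1)n1c(=O)c(C)nc2c(-c3ccc(Cl)cc3Cl)ncnc21` gives 0.004. Compound 3 `CC[C@@H](C1CC1)n1c(=O)c(C)nc2c(-c3ccc(Cl)cc3Cl)ccnc21` gives 0.002; its number and that of compound 2 lie within the scatter of each other, while the number of compound 1 stands beyond the scatter of compound 3.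

Going by the values given here, the one counted step among the measured compounds is 1-(methoxymethyl)propyl in place of 1-cyclopropylpropyl on an aromatic nitrogen; it brought a 5.5-fold higher number from compound 2 to compound 1 (0.74 log units; beyond the scatter). The difference between the core of compound 2 and the core of compound 3 is not broken down here.

Compound 4 `CC[C@H](COC)n1c(=O)c(C)nc2c(-c3ccc(Cl)cc3Cl)ccnc21` has not yet been measured in this assay. It stands to compound 3 as compound 1 stands to compound 2: 1-(methoxymethyl)propyl in place of 1-cyclopropylpropyl on an aromatic nitrogen. The surroundings of the place are described in the same words for both pairs, so this is the same change, now made on the core of compound 3. Among the compounds with values here, only a single measured example of the change exists, so the expectation rests on that one pair alone. Compound 4 is expected to show a 5.5-fold higher number from compound 3 to compound 4 (0.74 log units; beyond the scatter) because the same change gave a 5.5-fold higher number from compound 2 to compound 1 (0.74 log units; beyond the scatter). Compound 4 is therefore estimated at 0.011, with a range from 0.005 to 0.025.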

Compound 4, unbound fraction: 0.004
For compound 4 the middle estimate is 2.8-fold (0.44 log units) above the measured one; the measured number lies below the stated range.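

In this assay, placing 1-(methoxymethyl)propyl in place of 1-cyclopropylpropyl on the core of compound 3 brought a 2.0-fold higher number from compound 3 to compound 4 (0.30 log units; within the scatter), so on this core the change cannot be told apart from the ordinary spread of repeated measurements. The size of the step therefore did not carry over unchanged from one core to the other, and in this small set the effect of the swap depends on the core that carries it: the same change on two cores in this assay, a 5.5-fold higher number (0.74 log units; beyond the scatter) from compound 2 to compound 1 and a 2.0-fold higher number (0.30 log units; within the scatter) from compound 3 to compound 4, 2.8-fold (0.44 log units) apart, beyond the scatter of two such steps

This does not show which feature of the two cores governs the size of the step, nor whether the step on the core of compound 3 has a real direction, and two pairs give no basis for predicting the change on any further core.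

The compounds shown leave open how other groups on the aromatic nitrogen would behave on these two cores, for instance a side chain ending in a hydroxyl group, an amine or a carboxylic acid, or a longer chain. They also leave open whether any such replacement would give steps that agree between the cores more closely than this one did.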